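Lengthening the chain on a weakly active stereoisomer

This account rests on a few compounds, and the source may have more. Where it says the series, first, only, none or still open, it means among the compounds named here.

- compound 1 `CCCCCCCCn1cc(COC[C@@H]2OC[C@H](N)[C@@H]2O)nn1`: 28100 nM
- compound 2 `CCCCCCCCCn1cc(COC[C@@H]2OC[C@H](N)[C@@H]2O)nn1`: 12400 nM
- compound 3 `CCCCCCCCn1cc(COC[C@@H]2OC[C@H](N)[C@H]2O)nn1`: > 128000 nM

All three were tested in a functional assay on MCF7 cells (Homo sapiens) for antiproliferative activity, read by MTT assay, with a stated time of 48 h; a higher number here means a weaker inhibitor, a lower number a stronger inhibitor. For compound 3 the result is only a limit, > 128000 nM, and not a number.

The measured change of configuration gives an at least 4.5-fold higher number from compound 1 to compound 3 (0.65 log units; beyond the scatter), a step beyond the scatter that can be traced to the fact that compounds 1 and 3 differ only in the configuration as drawn.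

Compound 4 `CCCCCCCCCCn1cc(COC[C@@H]2OC[C@H](N)[C@H]2O)nn1` keeps the configuration of compound 3 and changes the chain: ethyl in place of hydrogen on a saturated chain carbon, eight bonds along the chain from an aromatic nitrogen. In words, ethyl takes the place of hydrogen on a saturated chain carbon, eight bonds along the chain from an aromatic nitrogen.

Among the measured compounds shown here, the closest precedent is methyl in place of hydrogen at that same place, a 2.3-fold lower number from compound 1 to compound 2 (0.36 log units; beyond the scatter), a modest step beyond the scatter, though measured in the other configuration. A somewhat larger step in the same direction, towards a lower number, is therefore expected in this assay.

The estimate means an at least 2.5-fold lower number from compound 3 to compound 4 (0.40 log units; beyond the scatter), an expected step with an uncertain size, as its starting point is a limit. For compound 4 the estimated value is 50000 nM, with an expected range of 15000 nM to 160000 nM.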

Compound 4, half-maximal inhibitory concentration: 45000 nM
The estimate for compound 4 lay 1.1-fold (0.05 log units) above the measured number; measured number inside the range.
By their numbers in this assay, from the lowest: compound 2; then compounds 1 and 4 (each within the scatter of the next). At a limit, above all of these: compound 3.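

In this assay, adding ethyl at this place gives an at least 2.8-fold lower number from compound 3 to compound 4 (0.45 log units; beyond the scatter), so the configuration of compound 3 still responds to a change in the chain. Among the compounds shown here, until now, the only step at this place was in the other configuration, a 2.3-fold lower number from compound 1 to compound 2 (0.36 log units; beyond the scatter), and the new step points the same way, towards a lower number. Compound 3 has a limit and not a number, so the true size of the new step cannot be read and cannot be ranked against the methyl step: the limit of > 128000 nM in this assay, at which 1 of the 4 values shown sits.

The compounds shown leave open whether a longer chain would lower the number further in either configuration, or whether a carboxylic acid in place of ethyl would keep the step. For the compounds shown here, they also give no step for ethyl at this place in the configuration of compound 1.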